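Carboxy to carbamoyl within a shared-core series

The compounds below may be only part of what the source reports. "The series", "measured", "known", "first", "only" and "open" are said of these compounds alone.

In a functional assay on the whole organism (Tail, strain ICR) with Mus musculus as the target, in the tail flick test, with a stated time of 30 min, at a dose of 25 umol/kg by the oral route (a higher number here means a stronger effect of the compound at the dose given, a lower number a weaker effect), compound 1 `CSCC[C@H](NC(=O)CN(c1nc(Cl)nc2[nH]cnc12)C1CC1)C(=O)OCc1ccccc1` gives 22.2%, compound 2 `C[C@@H](O)[C@H](NC(=O)CN(c1nc(Cl)nc2[nH]cnc12)C1CC1)C(=O)O` gives 18.6%, and compound 3 `O=C(O)CC[C@H](NC(=O)CN(c1nc(Cl)nc2[nH]cnc12)C1CC1)C(=O)O` gives 26.8%. Compound 3 carries the highest of the three numbers, but both gaps to it stay within the scatter, so no order among the three can be read. Going by the values given here, the one step between measured neighbours, a number 8.2 percentage points higher from compound 2 to compound 3 (within the scatter), is likewise within the scatter. Compound 4 `NC(=O)CC[C@H](NC(=O)CN(c1nc(Cl)nc2[nH]cnc12)C1CC1)C(=O)O` differs from compound 3 by amino in place of hydroxy on a carbonyl carbon. Among the compounds with values here, no measured step exchanges hydroxy for amino on a carbonyl carbon, so nothing bears directly on this change, and the only step available was small. The step of a number 2.8 percentage points lower from compound 3 to compound 4 (within the scatter) is therefore expected to lie within the scatter. The estimate for compound 4 in this assay is 24%, ranging from 9% to 40%.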

Compound 4, a percentage reported as activity, at one dose (the size of the read-out at that dose, not a potency): 33.1%
For compound 4 the middle estimate is 9.1 percentage points below the measured one; low and high end bracket the measured number.
By their numbers in this assay, from the lowest: compounds 2, 1, 3 and 4 (each within the scatter of the next, the first and the last beyond it).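

In this assay, the exchange on a carbonyl carbon gives a number 6.3 percentage points higher from compound 3 to compound 4 (within the scatter) and so does not separate carbamoyl from carboxy at this position. Against 1-hydroxyethyl, however, 2-carbamoylethyl gives a number 14.5 percentage points higher from compound 2 to compound 4 (beyond the scatter) as the first step in the series beyond the scatter, though a modest one, so this chain position can move the read-out. No evidence at hand accounts for either step. Still open, from the compounds shown here alone, is whether a longer chain ending in carbamoyl, or a primary amine at the chain end, would move the read-out further.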